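Same Small Change, Tried Again on a Rearranged Core

This account rests on a few compounds, and the source may have more. Where it says the series, first, only, none or still open, it means among the compounds named here.

Compound 1 `COc1cc(/C=C/C(O)=C/C(=O)/C=C/c2ccc(OC(=O)C(C)(CO)CO)c(OC)c2)ccc1O` gives 5940 nM in a functional assay on MDA-MB-231 cells (Homo sapiens) for antiproliferative activity, read by MTT assay, with a stated time of 72 h; a higher number here means a weaker inhibitor, a lower number a stronger inhibitor.
Compound 2 `CCC(CO)(CO)C(=O)Oc1ccc(/C=C/C(=O)/C=C(O)/C=C/c2ccc(O)c(OC)c2)cc1OC` gives 4660 nM in this assay.
Compound 3 `COc1ccc(/C=C/C(O)=C/C(=O)/C=C/c2ccc(OC)c(OC(=O)C(C)(CO)CO)c2)cc1O` gives 2290 nM in this assay.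

Compound 2 differs from compound 1 by methyl in place of hydrogen on a saturated chain carbon, two bonds along the chain from a carbonyl carbon, and the step was a 1.3-fold lower number from compound 1 to compound 2 (0.11 log units; within the scatter). Compound 3 has the same atoms as compound 1 joined differently; the difference between the two cores is not broken down here. Compound 4 `CCC(CO)(CO)C(=O)Oc1cc(/C=C/C(=O)/C=C(O)/C=C/c2ccc(OC)c(O)c2)ccc1OC` is still unmeasured and differs from compound 3 by methyl in place of hydrogen on a saturated chain carbon, two bonds along the chain from a carbonyl carbon, the same change as before, at the same place. Since that change moved compound 1 to compound 2 only within the scatter, the step is expected to be a 1.1-fold lower number from compound 3 to compound 4 (0.06 log units; within the scatter). Compound 4 is therefore estimated at 2000 nM, likely between 1000 nM and 4500 nM.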

Compound 4, half-maximal inhibitory concentration: 3850 nM
Estimate against measurement, compound 4: 1.9-fold (0.28 log units) below, and the stated range covers the measured number.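

Adding the methyl on the saturated chain carbon, which turns 1,1-bis(hydroxymethyl)ethyl into 1,1-bis(hydroxymethyl)propyl, gave a 1.7-fold higher number from compound 3 to compound 4 (0.23 log units; within the scatter) in this assay. Set beside the same change on the core of compound 1, the two steps cannot be told apart: the same change on two cores in this assay, a 1.3-fold lower number (0.11 log units; within the scatter) from compound 1 to compound 2 and a 1.7-fold higher number (0.23 log units; within the scatter) from compound 3 to compound 4, 2.1-fold (0.33 log units) apart, within the scatter of two such steps. On these two pairs the change therefore carries over from one core to the other as a step too small to read, but this does not prove that it acts identically on both cores, and it says nothing about any other core.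

The compounds shown leave open whether a longer chain than ethyl at this place would give a clear step on either core. The same question stands for a carboxylic acid in place of one hydroxymethyl group.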